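Working notes: from compound 2 to compound 3

The source may report more compounds than this note shows. Statements on the series, on what has been measured and on what is new or still open speak of the compounds shown alone.

Measured in a functional assay on G-361 cells (Homo sapiens) for antiproliferative activity, with a stated time of 72 h; a lower number here means a stronger inhibitor, a higher number a weaker inhibitor:
- compound 1 `COc1ccc(CNc2ncnc3c2ncn3[C@@H]2O[C@H](CO)[C@@H](O)[C@H]2O)c(OC)c1` | "not determined" (no result reported)
- compound 2 `OC[C@H]1O[C@@H](n2cnc3c(NCc4cc(F)cc(F)c4)ncnc32)C(O)C1O` | > 166000 nM

Compound 1 gives no number to compare. Compound 2 stands only at a limit of the assay, > 166000 nM, and not at a measured number. Within the data shown here, that limit is the sole reading: the limit of > 166000 nM in this assay, at which 1 of the 2 values shown sits.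

The next compound is compound 3 `OC[C@H]1O[C@@H](n2cnc3c(NCc4ccccc4C(F)(F)F)ncnc32)C(O)C1O`. The change from compound 2 is 2-(trifluoromethyl)phenyl in place of 3,5-difluorophenyl on a saturated chain carbon bound to a nitrogen on an aromatic ring. In short, 2-(trifluoromethyl)phenyl comes in place of 3,5-difluorophenyl on a saturated chain carbon bound to a nitrogen on an aromatic ring.

Among the measured compounds shown here, no measured step exists to size this change. In this assay no step beyond the usual scatter is expected, and no direction can be assigned. A report of compound 3 as a limit too would not be a surprise.

The expected change is a number no higher from compound 2 to compound 3 (the limit leaves the size open).

For compound 3 the estimated value is 166000 nM, with an expected range from 40000 nM to 400000 nM.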

Compound 3, half-maximal inhibitory concentration: > 166000 nM
Compound 3 gave a limit, no number (the forecaster's own chance of this, stated with the estimate: 70%); the middle value lies on the limit itself.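

In this assay compound 2 and compound 3 both stand at a limit, so no step can be read between them: the limit of > 166000 nM in this assay, at which 2 of the 3 values shown sit.

The compounds shown leave open how far 2-(trifluoromethyl)phenyl and 3,5-difluorophenyl differ in effect, and whether any compound in this series gives a number rather than a limit.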